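Replacing the tert-butoxycarbonyl group: a cytotoxicity expectation

The source may hold more compounds than are shown below. What is called first, only, known or untested is meant among the compounds shown, and "the series" means these compounds.

Compound 1 `CC(C)(C)OC(=O)c1ccc(CN2C(=O)c3ccccc3S2(=O)=O)cc1` — > 100000 nM
Compound 2 `NC(=O)c1ccc(CN2C(=O)c3ccccc3S2(=O)=O)cc1` — > 100000 nM
Compound 3 `CC(C)(C)OC(=O)N(C(=O)OC(C)(C)C)C(=O)c1ccc(CN2C(=O)c3ccccc3S2(=O)=O)cc1` — > 100000 nM

In an ADME assay on RAW264.7 cells (Mus musculus) for cytotoxicity, read by WST assay (a higher number here means that more compound is tolerated, a lower number that less compound is tolerated), compound 1 gives > 100000 nM, which is a limit of the assay and not a number. Compound 2 gives > 100000 nM, again only a limit. Compound 3 gives > 100000 nM, also a limit. Compound 3 therefore stands together with the other two measured compounds at the limit of > 100000 nM in this assay, at which 3 of the 3 values shown sit; nothing in the numbers separates it from compound 1 or compound 2. For the measured compounds named here, the only step between measured compounds that differ in one place, a step that the two limits leave unreadable from compound 1 to compound 2, is left unreadable by the two limits, so it gives no size that could be carried over.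

Compound 4 `CN(C(=O)OC(C)(C)C)C(=O)c1ccc(CN2C(=O)c3ccccc3S2(=O)=O)cc1` differs from compound 3 by methyl in place of tert-butoxycarbonyl on an amide-type nitrogen. Going by the values given here, no measured step reads on this change; what is known is only that every measured compound sits at the limit. The step that the limit leaves unreadable from compound 3 to compound 4 is accordingly expected to be none beyond the scatter. For compound 4 the estimate in this assay is 150000 nM, within a range from 50000 nM to 500000 nM, and most likely the assay will again report only a limit.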

Compound 4, concentration lethal to 50% of the cells: > 100000 nM
Compound 4 gave a limit, no number; the forecaster's own chance of this, stated with the estimate: 85%; the middle value does not contradict the limit.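

None of the steps from compound 1, compound 2 or compound 3 to compound 4 can be read in this assay, and all four compounds stand together: the limit of > 100000 nM in this assay, at which 4 of the 4 values shown sit.

The compounds shown leave open how much of any of these four compounds the cells actually tolerate, and so whether the changes among them make any difference in this assay.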